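The source may report more compounds than this note shows. Statements on the series, on what has been measured and on what is new or still open speak of the compounds shown alone.

Measured so far in a functional assay on NCI-H460 cells (Homo sapiens) for antiproliferative activity, read by MTT assay, with a stated time of 48 h; on this read-out lower numbers stand for stronger inhibition and higher numbers for weaker inhibition:
- compound 1, `CC1(C)Cc2c(OCc3ccccc3)ccc(C(=O)/C=C/c3ccc(F)cc3)c2O1`: 22300 nM
- compound 2, `CC1(C)Cc2c(ccc(C(=O)/C=C/c3ccc(Cl)cc3)c2OCc2ccccc2)O1`: > 100000 nM
- compound 3, `COc1ccc(-c2nn(-c3ccccc3)cc2/C=C/C(=O)c2ccc3c(c2OCc2ccccc2)CC(C)(C)O3)cc1`: > 100000 nM

Compound 2 has no number in this assay, only a limit: compound 2 sits at > 100000 nM. The same holds for compound 3, which also reaches only > 100000 nM in this assay. Among the three values shown, compound 1 is the one that gives a number, 22300 nM in this assay; the other two sit at the limit of > 100000 nM in this assay, at which 2 of the 3 values shown sit.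

Compound 4, `CC1(C)Cc2c(ccc(C(=O)/C=C/c3ccc(F)cc3)c2OCc2ccccc2)O1`, is not yet measured in this assay. It comes from compound 2 by one change: fluoro in place of chloro on an aromatic carbon, that carbon being para to a large group. For the measured compounds named here, no measured pair in this assay shows the size of such a swap. Given that compound 2 stands at a limit, the expectation for compound 4 is no step beyond the scatter, with the step from compound 2 to compound 4 estimated as an at least 1.1-fold lower number from compound 2 to compound 4 (0.04 log units; that floor lies within the scatter). Compound 4 is therefore expected near 90000 nM in this assay, within a range of 20000 nM to 400000 nM, and a reported limit rather than a number is the more likely outcome.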

Compound 4, half-maximal inhibitory concentration: 75800 nM
The estimate for compound 4 lay 1.2-fold (0.07 log units) above the measured number; measured number inside the range.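

In this assay, for the compounds shown here, the change from 4-chlorophenyl to 4-fluorophenyl is the first single-place change that can be read, and it gives an at least 1.3-fold lower number from compound 2 to compound 4 (0.12 log units; that floor lies within the scatter). With fluoro on this aromatic carbon, para to a large group, compound 4 gives a number, 75800 nM, rather than a limit, but the step does not establish a real gain over chloro. Only a floor can be stated for the step, because compound 2 carries a limit and not a number: the limit of > 100000 nM in this assay, at which 2 of the 4 values shown sit.

On these data alone, the true size of the step remains open, since it could still prove larger than this floor. Also open, as far as these compounds go, is whether an amine or a carboxylic acid on this same carbon would shift the number beyond the scatter.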